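This account rests on a few compounds, and the source may have more. Where it says the series, first, only, none or still open, it means among the compounds named here.

Measured in an assay for inhibition of Indoleamine 2,3-dioxygenase 1 (Homo sapiens), read by fluorescence, with a stated time of 24 h; a lower number here means a stronger inhibitor, a higher number a weaker inhibitor:
compound 1 `NS(=O)(=O)NCCSc1nonc1/C(=N/O)Nc1ccc(F)c(Br)c1`: 2.8 nM
compound 2 `NS(=O)(=O)CC(=O)NCCSc1nonc1/C(=N/O)Nc1ccc(F)c(C(F)F)c1`: 13 nM
compound 3 `N#Cc1cc(N/C(=N\O)c2nonc2SCCNC(=O)CS(N)(=O)=O)ccc1F`: 39 nM

Compound 1 stands lowest of the three numbers; compound 2 sits nearest and compound 3 furthest, both beyond the scatter. Among the measured compounds shown here, the one measured step, a 3.0-fold higher number from compound 2 to compound 3 (0.48 log units; beyond the scatter), lies on the aryl ring and not on the core. Compound 4 `COc1nonc1/C(=N/O)Nc1ccc(F)c(Br)c1` is obtained from compound 1 by methoxy in place of (2-(sulfamoylamino)ethyl)sulfanyl on an aromatic carbon. For the measured compounds named here, no measured step touches this position, and every measured compound carries the longer chain, so there is no direct read on its removal; the expectation rests only on that absence. Compound 4 is estimated to give 60 nM (range 10 nM to 400 nM), which means an expected step of a 21-fold higher number from compound 1 to compound 4 (1.33 log units; beyond the scatter), with wide uncertainty.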

Compound 4, half-maximal inhibitory concentration: 39 nM
For compound 4 the middle estimate is 1.5-fold (0.19 log units) above the measured one; the measured number falls inside the stated range.
By their numbers in this assay, from the lowest: compound 1; then compound 2; then compounds 3 and 4 (each within the scatter of the next).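

In this assay the replacement of (2-(sulfamoylamino)ethyl)sulfanyl by methoxy gives a 14-fold higher number from compound 1 to compound 4 (1.14 log units; beyond the scatter) as the first read on this position. The number therefore depends on what sits on this aromatic carbon, though compound 4 stays measurable in this assay without the longer chain. No evidence bears on the cause of this step.
As far as these compounds go, whether the difference lies in the sulfanyl link or in the terminal sulfamoylamino group remains open. A methylsulfanyl group or a 2-aminoethylsulfanyl chain on this carbon would separate the two.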